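From benzyl to 4-methylbenzyl in compound 4

A few compounds are considered here, and "the series" means these few. Any claim that something is new, unique, unknown or untested is made for them only; others in the source may bear on it.

Measured in a functional assay on RS4-11 cells (Homo sapiens) for inhibition, read by CCK-8 assay, with a stated time of 48 h, tested at 20 uM; a higher number here means more inhibition of growth at the concentration tested, a lower number less inhibition of growth:
compound 1 `Cc1ccc(S(=O)(=O)Oc2ccccc2/C=C(\C#N)C(=O)Nc2nnc(Cc3ccccc3)s2)cc1`: 69%
compound 2 `N#C/C(=C\c1ccccc1OS(=O)(=O)c1ccc([N+](=O)[O-])cc1)C(=O)Nc1nnc(Cc2ccccc2)s1`: 57%
compound 3 `N#C/C(=C\c1ccccc1OS(=O)(=O)c1ccc(Cl)cc1)C(=O)Nc1nnc(Cc2ccccc2)s1`: 73%

The data show a number 4 percentage points higher from compound 1 to compound 3 (within the scatter), which leaves those two together at the top of this small set. They also show a number 16 percentage points higher from compound 2 to compound 3 (beyond the scatter).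

The next compound, compound 4 `Cc1ccc(Cc2nnc(NC(=O)/C(C#N)=C/c3ccccc3OS(=O)(=O)c3ccc(Cl)cc3)s2)cc1`, keeps all of compound 3 except that benzyl becomes 4-methylbenzyl: methyl in place of hydrogen on an aromatic carbon. Going by the values given here, none of the measured steps touches this spot, since all three swap a different group, so they can only suggest a likely size. Those swaps gave a number 12 percentage points lower from compound 1 to compound 2 (beyond the scatter) at most, and the others were no larger than the modest a number 16 percentage points higher from compound 2 to compound 3 (beyond the scatter). A single methyl on an untested spot therefore gives no grounds for a direction, and no change beyond the scatter is the most likely outcome, although a modest step either way remains possible.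

The expected step is a number 2 percentage points lower from compound 3 to compound 4 (within the scatter).

The estimate for compound 4 is 71%, with an expected range of 58% to 84%.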

Compound 4, percent growth inhibition at one concentration: 72%
For compound 4 the middle estimate is 1 percentage points below the measured one; measured number inside the range.
By their numbers in this assay, from the lowest: compound 2; then compounds 1, 4 and 3 (each within the scatter of the next).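

In this assay, the methyl on the benzyl group, placed on an aromatic carbon para to a large group, gives a number 1 percentage points lower from compound 3 to compound 4 (within the scatter). Going by these compounds alone, all the earlier steps changed a group elsewhere in the molecule, so this is the first reading at this spot. It shows that this one methyl can be added to the benzyl group of compound 3 without a readable change in growth inhibition at the concentration tested. No measurement shown here offers an explanation for this result.

A single methyl says little about how much room for change this spot allows, so an amine, a carboxylic acid or a longer chain such as propyl could behave quite differently. The same methyl at other carbons of that ring also remains an open comparison.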